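Aryl-alkyne amides as mGlu5 positive modulators: thiophene variant

The source may hold more compounds than are shown below. What is called first, only, known or untested is meant among the compounds shown, and "the series" means these compounds.

Measured compounds, with values in a functional assay on HEK293 cells for positive allosteric modulation of metabotropic glutamate receptor 5 (Homo sapiens), read by FLIPR and calcium flux; on this read-out lower numbers stand for an effect already at smaller amounts and higher numbers for an effect only at larger amounts of compound:
compound 1, `O=C(NC1CCCC1)c1ccc(C#Cc2cccnc2)nc1`, gives > 10000 nM, which is a limit of the assay and not a number.
compound 2, `O=C1c2ccc(C#Cc3ccccc3)nc2CCN1C1CCCC1`, gives 5.9 nM.
compound 3, `Cc1ccccc1C#Cc1ccc2c(n1)CCN(C1CCCCC1)C2=O`, gives 466 nM.

Compound 3 stands at the highest of the two numbers in this assay; the nearest is compound 2 with a lower number, and the gap between them lies beyond the scatter. For the measured compounds named here, compound 2 and compound 3 differ in two places at once, so no single step between measured compounds is available. The limit seen for compound 1 is noted as the limit of > 10000 nM in this assay, at which 1 of the 3 values shown sits, and carries no further weight here.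

The next compound, compound 4, `O=C1c2ccc(C#Cc3cccs3)nc2CCN1C1CCCCC1`, differs from compound 3 in one place: thiophen-2-yl in place of 2-methylphenyl on a triple-bonded carbon. In this assay, going by the values given here, a step from compound 3 to compound 4 toward a lower number is expected, since the only measured number clearly below compound 3 belongs to compound 2 with 5.9 nM, carrying phenyl rather than 2-methylphenyl on the triple-bonded carbon, though compound 2 also carries cyclopentyl rather than cyclohexyl. The expected step is a 9.3-fold lower number from compound 3 to compound 4 (0.97 log units; beyond the scatter). For compound 4 the estimate in this assay is 50 nM, with a range from 8 nM to 300 nM.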

Compound 4, half-maximal effective concentration: 13 nM
The estimate for compound 4 lay 3.8-fold (0.59 log units) above the measured number; low and high end bracket the measured number.
By their numbers in this assay, from the lowest: compound 2; then compound 4; then compound 3. At a limit, above all of these: compound 1.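

In this assay, for the compounds shown here, the first single-place comparison of the series shows that this position, on a triple-bonded carbon, responds strongly to the group it carries: with the rest of the structure unchanged, the step is a 36-fold lower number from compound 3 to compound 4 (1.55 log units; beyond the scatter). The change also shows that a six-membered aromatic ring of carbon only is not needed at this position, since compound 4, with a five-membered aromatic ring holding one sulfur atom, gives 13 nM in this assay. No measured property among the data shown bears on the size of this step.

Going by these compounds, it remains open whether the step comes from losing the methyl group or from exchanging the ring itself, a question that plain phenyl on the same cyclohexyl amide would separate. Also open, on these data alone, are how far this position accepts other groups, such as furan-2-yl or a phenyl ring carrying an amine, and whether thiophen-2-yl behaves the same way when cyclohexyl gives way to cyclopentyl.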